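The compounds below may be only part of what the source reports. "The series", "measured", "known", "first", "only" and "open" are said of these compounds alone.

Compound 1 (`OCCCSC(=S)NCc1cccnc1`): in a functional assay on SK-BR-3 cells (Homo sapiens) for cytotoxicity, read by resazurin assay, with a stated time of 72 h (on this read-out lower numbers stand for stronger inhibition and higher numbers for weaker inhibition), compound 1 gives 1320 nM. Compound 2 (`O=C(CCSC(=S)NCc1cccnc1)NCc1ccccc1`): in this assay compound 2 reaches only a limit, > 100000 nM.

Going by the values given here, compound 1 thus holds the only numerical value shown; the other entry is the limit of > 100000 nM in this assay, at which 1 of the 2 values shown sits. Compound 3 (`O=S(=O)(O)CCCSC(=S)NCc1cccnc1`) differs from compound 1 by sulfo in place of hydroxy on a saturated chain carbon, three bonds along the chain from a sulfur. Among the compounds with values here, no measured pair shows this change, so the expected step from compound 1 to compound 3 is an estimate: a loss of potency beyond the scatter, a 7.6-fold higher number from compound 1 to compound 3 (0.88 log units; beyond the scatter). Compound 3 is accordingly expected to give about 10000 nM, within 2000 nM to 100000 nM.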

Compound 3, half-maximal inhibitory concentration: 6770 nM
The estimate for compound 3 lay 1.5-fold (0.17 log units) above the measured number; low and high end bracket the measured number.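

Going by these compounds alone, the change from hydroxy to sulfo on a saturated chain carbon, three bonds along the chain from a sulfur, now has a measured size, which the earlier compounds did not give: in this assay it produces a 5.1-fold higher number from compound 1 to compound 3 (0.71 log units; beyond the scatter). The loss is modest but beyond the scatter, and compound 3 still gives a numerical value rather than a limit. No measurement shown explains this step.

The compounds shown leave open how a carboxylic acid or an amine would fare in this place. They also leave open the effect of a longer chain.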